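Pyrimidin-2-yl to 5-chloropyrimidin-2-yl: compound 1 to compound 3

The source may report more compounds than this note shows. Statements on the series, on what has been measured and on what is new or still open speak of the compounds shown alone.

Measured so far:
compound 1, `CS(=O)(=O)c1ccc2c(c1)CCN2c1ncnc2c(C3CCN(c4ncccn4)CC3)coc12`: 196%
compound 2, `CC(C)(C)OC(=O)N1CCC(c2coc3c(Nc4ccc(S(C)(=O)=O)cc4F)ncnc23)CC1`: 123%

In a functional assay on cells for agonist activity at Glucose-dependent insulinotropic receptor (Homo sapiens), read by a luciferase reporter, with a stated time of 4 h (on this read-out higher numbers stand for larger maximal responses and lower numbers for smaller maximal responses), compound 1 gives 196% and stands highest of the two numbers. Among the compounds with values here, compound 2 gives 123% in this assay, a gap that lies beyond the scatter of repeated measurements; no single-point step connects these two compounds, so the pair shows only that compound 1 reaches the larger maximal response.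

Compound 3, `CS(=O)(=O)c1ccc2c(c1)CCN2c1ncnc2c(C3CCN(c4ncc(Cl)cn4)CC3)coc12`, differs from compound 1 in one place: chloro in place of hydrogen on an aromatic carbon. Within the data shown here, no step of this kind has been measured, so nothing here tells how a chloro on that aromatic carbon alters the maximal response. The expectation is a small step from compound 1 to compound 3 in this assay, most likely none beyond the scatter, with the downward side somewhat more open. The estimated step is a number 11 percentage points lower from compound 1 to compound 3 (beyond the scatter). Compound 3 is expected to give about 185% in this assay, within a range of 140% to 225%.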

Compound 3, largest response reached (Emax), in percent of the reference or control that the assay uses: 117%
Beside the measured number, compound 3's estimate is 68 percentage points above it, and the stated range ends above it.
By their numbers in this assay, from the lowest: compounds 3 and 2 (each within the scatter of the next); then compound 1.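

In this assay, chloro in place of hydrogen on this aromatic carbon, two atoms from the ring nitrogen and para to a large group, gives a large drop: a number 79 percentage points lower from compound 1 to compound 3 (beyond the scatter). Within the data shown here, the maximal response therefore depends on this position of the pyrimidin-2-yl group, and a single chlorine atom is enough to change it, which the earlier pair, with no one-place step between its members, could not show. No measurement at hand bears on the origin of this drop.

From the compounds shown here alone, whether the drop belongs to chloro itself or would follow any group at this carbon remains open; fluoro, methyl, methoxy or an amine at the same place would separate these cases. Also open, going by these compounds, is whether the same change lowers the maximal response on other cores of the series.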